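The compounds below may be only part of what the source reports. "The series", "measured", "known", "first", "only" and "open" are said of these compounds alone.

Measured compounds in the series so far:
compound 1, `CCN1C(=O)CCN(S(=O)(=O)c2ccc(-n3nc(C)cc3C)cc2)C1=S`, 4%
compound 2, `Cc1cc(C(=O)O)nn1-c1ccc(S(=O)(=O)N2CCC(=O)N(Cc3ccccc3)C2=S)cc1`, 16%

In a functional assay on the whole organism (blood, strain albino) with Mus musculus as the target, with stated times of 6 days and 3 h, at a dose of 1 mmol/kg by the oral route (a lower number here means less inhibition, a higher number more inhibition at the dose given (going by the name of the read-out)), compound 2 gives 16%, the higher of the two numbers; compound 1 gives 4%, a gap that lies beyond the scatter. Compound 3, `Cc1cc(C)n(-c2ccc(S(=O)(=O)N3CCC(=O)N(Cc4ccccc4)C3=S)cc2)n1`, has not been measured in this assay. It differs from compound 2 in one place: methyl in place of carboxy on an aromatic carbon.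

Among the compounds with values here, no pair of measured compounds differs in exactly one place, so there is no measured step to lean on. The expected step of a number 9 percentage points lower from compound 2 to compound 3 (within the scatter) points downward and is estimated to exceed the scatter, because compound 1 gives 4% and sits well under compound 2. For compound 3 the estimated inhibition is 7%, with a range from 0% to 20%.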

Compound 3, a percentage reported as inhibition, in the whole organism at one dose (the size of the read-out at that dose, not a potency): 18%
The estimate for compound 3 lay 11 percentage points below the measured number; measured number inside the range.
By their numbers in this assay, from the lowest: compound 1; then compounds 2 and 3 (each within the scatter of the next).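

In this assay, the step of a number 2 percentage points higher from compound 2 to compound 3 (within the scatter) shows that carboxy and methyl on this aromatic carbon of the five-membered aromatic ring cannot be told apart in the read-out. Going from 3-carboxy-5-methyl-1H-pyrazol-1-yl to 3,5-dimethyl-1H-pyrazol-1-yl therefore leaves the number within the usual spread, so the carboxy group is not needed for the inhibition seen at this dose. The change that does register lies elsewhere: phenyl in place of methyl on the saturated chain carbon bound to an amide-type nitrogen in a ring gives a number 14 percentage points higher from compound 1 to compound 3 (beyond the scatter) and this modest step is the only one here beyond the scatter.

Still open, from the compounds shown here alone, is how an amine or a longer chain on the same aromatic carbon would read, and whether a longer chain in place of that phenyl would hold the gain. Nothing on hand accounts for either step.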